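This account rests on a few compounds, and the source may have more. Where it says the series, first, only, none or still open, it means among the compounds named here.

Measured compounds, with the number each gives in a physicochemical assay, with a stated time of 30 min; a lower number here means a stronger inhibitor, a higher number a weaker inhibitor:
compound 1 `COc1cc2c(cc1OC)C(=O)C(C(=O)Nc1ccccc1)C2`, compound 1 gives 61.3 ug/mL
compound 2 `COc1cc2c(cc1OC)C(=O)C(C(=O)Nc1ccc(Br)cc1)C2`, compound 2 gives 72.1 ug/mL

Compound 1 and compound 2 share one core and differ only at one aromatic carbon of the anilide ring. Compound 1 is the reference point here; compound 2 departs from it by a 1.2-fold higher number from compound 1 to compound 2 (0.07 log units; within the scatter), and that is within the scatter, so the two compounds are not distinguished by this assay. Nothing beyond these two numbers is known for the series.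

Compound 3 `COc1cc2c(cc1OC)C(=O)C(C(=O)Nc1ccccc1C)C2` is not yet measured. It differs from compound 1 by methyl in place of hydrogen on an aromatic carbon. Among the measured compounds shown here, the only measured step that bears on a substituent at an aromatic carbon of the anilide ring is a 1.2-fold higher number from compound 1 to compound 2 (0.07 log units; within the scatter), which shows no movement beyond the scatter. That step concerns bromo at a different place, so it is a loose guide only. Compound 3 is therefore expected to sit close to compound 1, with a 1.1-fold higher number from compound 1 to compound 3 (0.03 log units; within the scatter) as the estimated step. For compound 3 the expected number in this assay is 65 ug/mL, with a range of 35 ug/mL to 120 ug/mL.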

Compound 3, half-maximal inhibitory concentration: 43.7 ug/mL
Compound 3: middle estimate off by 1.5-fold (0.17 log units), on the high side; low and high end bracket the measured number.
By their numbers in this assay, from the lowest: compounds 3, 1 and 2 (each within the scatter of the next).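

In this assay, methyl on an aromatic carbon of the six-membered aromatic ring of carbon only, ortho to a large group, gives a 1.4-fold lower number from compound 1 to compound 3 (0.15 log units; within the scatter) and stays within the scatter, so this position accepts one added carbon without a distinguishable shift in the read-out. Among the compounds shown here, the exchange of 4-bromophenyl for 2-methylphenyl on the amide-type nitrogen gives a 1.6-fold lower number from compound 2 to compound 3 (0.22 log units; within the scatter) and also stays within the scatter, which extends the finding from the single bromo change to a second substituent, a second place on the ring and a direct comparison of the two substituted compounds, with none of the three compounds distinguished from another. No supporting data bear on this result, and the numbers alone assign it no cause.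

Still open, going by these compounds, is whether a carboxylic acid, an amine or a longer chain such as propyl at this same place would move the number beyond the scatter, or whether this position stays as flat as the methyl result suggests. Also open, on these data alone, is how methyl would read at the place that carries bromo in compound 2, and whether hydroxy or methoxy at either place would separate from compound 1.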